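The compounds below may be only part of what the source reports. "The series", "measured", "known", "first", "only" and "open" are said of these compounds alone.

Compound 1 `COc1ccc(Cc2nnc3n2N=C(c2ccc(Cl)cc2)CS3)cc1` gives 9.9%.
Compound 2 `COc1ccc(Cc2nnc3n2N=C(c2ccc(F)cc2)CS3)cc1` gives 20.5%.
Compound 3 `COc1ccc(CCc2nnc3n2N=C(c2ccc(Cl)cc2)CS3)cc1` gives 20.2%.

The three measured compounds were tested in a functional assay on the whole organism (strain BALB/c) with Mus musculus as the target, in the writhing test, with a stated time of 1 h, at a dose of 50 mg/kg by the oral route; a higher number here means a stronger effect of the compound at the dose given, a lower number a weaker effect. Compound 1 gives 9.9%, and compound 2 gives 20.5%. The step between them, a number 10.6 percentage points higher from compound 1 to compound 2 (beyond the scatter), goes with the change (fluoro in place of chloro on an aromatic carbon). Compound 3 gives 20.2%, a number that lies within the scatter of the number for compound 2 and beyond the scatter of the number for compound 1. How the core of compound 3 differs from the core of compound 1 is not broken down here.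

Compound 4 `COc1ccc(CCc2nnc3n2N=C(c2ccc(F)cc2)CS3)cc1` has not yet been measured in this assay. It differs from compound 3 by fluoro in place of chloro on an aromatic carbon, and the place of this change is the same, word for word, as the place of the change from compound 1 to compound 2, so it is the same change made on the core of compound 3. Going by the values given here, the one measured instance of the change, a number 10.6 percentage points higher from compound 1 to compound 2 (beyond the scatter), is the only ground for an expectation, and it rests on a single pair. Set beside that earlier step, the step of a number 8.8 percentage points higher from compound 3 to compound 4 (within the scatter) is expected to be of a similar size, because the earlier step of a number 10.6 percentage points higher from compound 1 to compound 2 (beyond the scatter) lay beyond the scatter. For compound 4 the estimate in this assay is 29%, expected to fall between 16% and 42%.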

Compound 4, a percentage reported as inhibition, in the whole organism at one dose (the size of the read-out at that dose, not a potency): 25%
Estimate against measurement, compound 4: 4 percentage points above; measured number inside the range.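

Carried to the core of compound 3, fluoro in place of chloro on an aromatic carbon gives, in this assay, a number 4.8 percentage points higher from compound 3 to compound 4 (within the scatter), so on this core the step cannot be told apart from the usual scatter of repeated measurements. Set beside the earlier step, the new one does not differ from it by more than the scatter allows: the same change on two cores in this assay, a number 10.6 percentage points higher (beyond the scatter) from compound 1 to compound 2 and a number 4.8 percentage points higher (within the scatter) from compound 3 to compound 4, 5.8 percentage points apart, within the scatter of two such steps. Going by these compounds alone, the two steps can therefore be read as compatible with a step of similar size on both cores, but only the step on the core of compound 1 lies beyond the scatter, so the data do not show a reliable effect of the change on the core of compound 3, and two pairs make no rule for the series.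

The compounds shown leave open whether bromo, trifluoromethyl or a nitrile in the same place would give a number like that of fluoro or of chloro. Within the data shown here, they also leave open whether a longer chain than the one in compound 3, or an amine on that chain, would alter the size of the step, and how the step would look at another dose in this assay.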